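A few compounds are considered here, and "the series" means these few. Any claim that something is new, unique, unknown or untested is made for them only; others in the source may bear on it.

Compound 3 `CC1CCN(c2c(S(=O)(=O)c3ccccc3)cnc3cc(F)ccc23)CC1` gives 87% in an assay on isolated protein for displacement of a labelled ligand from metabotropic glutamate receptor 5 (Homo sapiens), with a stated time of 60 min, tested at 1 uM; on this read-out higher numbers stand for more inhibition at the one concentration tested (going by the name of the read-out) and lower numbers for less inhibition. Compound 1 `COc1ccc(S(=O)(=O)c2cnc3cc(F)ccc3c2N2CCC(C)CC2)cc1OC` gives 83% and compound 2 `CC1CCN(c2c(S(=O)(=O)c3ccc(C#N)cc3)cnc3cc(F)ccc23)CC1` gives 83%, so the change was a number 4 percentage points higher from compound 1 to compound 3 (within the scatter) and a number 4 percentage points higher from compound 2 to compound 3 (within the scatter); all three numbers sit together. Compound 4 `COc1cccc(S(=O)(=O)c2cnc3cc(F)ccc3c2N2CCC(C)CC2)c1` differs from compound 3 by methoxy in place of hydrogen on an aromatic carbon. The step that bears on this is the removal of two methoxy groups from the same ring, a number 4 percentage points higher from compound 1 to compound 3 (within the scatter), together with the exchange of cyano for hydrogen, a number 4 percentage points higher from compound 2 to compound 3 (within the scatter); neither moved the read-out beyond the scatter. A single methoxy entering is therefore expected to give no step beyond the scatter, a number 2 percentage points lower from compound 3 to compound 4 (within the scatter). Compound 4 is estimated at 85%, between 74% and 94%.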

Compound 4, a percentage reported as inhibition, at one concentration (the size of the read-out at that concentration, not a potency): 90%
For compound 4 the middle estimate is 5 percentage points below the measured one; low and high end bracket the measured number.
By their numbers in this assay, from the lowest: compounds 1, 2, 3 and 4 (each within the scatter of the next).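

In this assay, a single methoxy meta to a large group on the phenyl attached to the sulfonyl sulfur gives a number 3 percentage points higher from compound 3 to compound 4 (within the scatter). Hydrogen in place of the other methoxy gives a number 7 percentage points higher from compound 1 to compound 4 (within the scatter), and 3-methoxyphenyl in place of 4-cyanophenyl gives a number 7 percentage points higher from compound 2 to compound 4 (within the scatter), so neither the second methoxy nor the exchange of the whole aryl group separates these compounds beyond the scatter. No measurement here accounts for this flat picture.

From the compounds shown here alone, whether an amine or a carboxylic acid at this place would leave the read-out unmoved remains open. As these are percentages at one concentration, they also leave open how the compounds compare in potency.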